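The compounds below may be only part of what the source reports. "The series", "measured", "known", "first", "only" and "open" are said of these compounds alone.

Of the compounds shown here, three built on one shared core have been measured in an assay on isolated protein for inhibition of protein kinase C zeta type (Homo sapiens), with stated times of 1 h and 2.5 min, tested at 30 uM; on this read-out lower numbers stand for less inhibition and higher numbers for more inhibition at the one concentration tested (going by the name of the read-out). Compound 1 `COCC(C)OC(=O)c1c(-c2ccc(OC)c(OC)c2)csc1N` gives 49% in this assay. Compound 2 `COc1ccc(-c2csc(N)c2C(=O)Oc2ccccc2)cc1OC` gives 48%, and the step of a number 1 percentage points lower from compound 1 to compound 2 (within the scatter) lies within the scatter. Compound 3 `COc1ccc(-c2csc(N)c2C(=O)OCc2cccc(C)c2)cc1OC` gives 67%, the highest of the three numbers; the nearest neighbour is compound 1 and the furthest is compound 2, and both gaps lie beyond the scatter. The steps of a number 18 percentage points higher from compound 1 to compound 3 (beyond the scatter) and a number 19 percentage points higher from compound 2 to compound 3 (beyond the scatter) are both modest and both point upward.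

Compound 4 `COc1ccc(-c2csc(N)c2C(=O)OCc2ccccc2F)cc1OC` differs from compound 3 in one place: 2-fluorophenyl in place of 3-methylphenyl on a saturated chain carbon bound to an oxygen next to a carbonyl group. The two measured steps that touch this region both replace a smaller group by 3-methylbenzyl on the oxygen next to the carbonyl group, and neither compares one benzyl group against another. Going by the values given here, no measured step therefore bears directly on the move from 3-methylphenyl to 2-fluorophenyl on the saturated chain carbon bound to that oxygen. The series offers no comparison of this kind. The expected step of a number 7 percentage points lower from compound 3 to compound 4 (within the scatter) is a small one, not beyond the scatter, with a slight lean downward. Compound 4 is accordingly estimated to give 60% in this assay, within a range from 42% to 76%.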

Compound 4, a percentage reported as inhibition, at one concentration (the size of the read-out at that concentration, not a potency): 100%
Compound 4: the middle estimate sits 40 percentage points below what was measured; the whole stated range lies below it.
By their numbers in this assay, from the lowest: compounds 2 and 1 (each within the scatter of the next); then compound 3; then compound 4.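

The swap on the saturated chain carbon bound to an oxygen next to a carbonyl group shows that in this assay the read-out depends on which benzyl group is present and not merely on having one, since the exchange of two groups with the same heavy-atom count gives a number 33 percentage points higher from compound 3 to compound 4 (beyond the scatter). The earlier steps shown here to compound 3 were modest, whereas 2-fluorobenzyl gives a number 52 percentage points higher from compound 2 to compound 4 (beyond the scatter) and likewise a number 51 percentage points higher from compound 1 to compound 4 (beyond the scatter), so the range spanned by changes on this oxygen is much wider than the first three compounds suggested. Nothing available here accounts for the difference between the two benzyl groups.

The step from compound 3 to compound 4 changes both the substituent and the number in its name, so the compounds shown cannot tell whether the fluorine or its placement carries the gain, a question that unsubstituted benzyl, 3-fluorobenzyl and 2-methylbenzyl would bear on. They also leave open whether 2-chlorobenzyl or 2-methoxybenzyl would behave like 2-fluorobenzyl, and, with a single tested concentration, how compound 3 and compound 4 compare in potency.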